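The source may report more compounds than this note shows. Statements on the series, on what has been measured and on what is new or still open speak of the compounds shown alone.

In a functional assay on DU-145 cells (Homo sapiens) for cytotoxicity, read by trypan blue exclusion, with a stated time of 96 h (on this read-out higher numbers stand for weaker inhibition and lower numbers for stronger inhibition), compound 1 `COc1cc(OC)c(/C=C/S(=O)(=O)Nc2ccc(F)c(N)c2)c(OC)c1` gives 10000 nM. Compound 2 `COc1ccc(NS(=O)(=O)/C=C/c2c(F)c(F)c(F)c(F)c2F)cc1F` gives 10000 nM, and compound 3 `COc1ccc(NS(=O)(=O)/C=C/c2c(OC)cc(O)cc2OC)cc1` gives 10000 nM. Compound 1 therefore stands level with both, and these three values offer no measured step to reason from. Compound 4 `COc1cc(OC)c(/C=C/S(=O)(=O)Nc2ccc(OC)c(F)c2)c(OC)c1` keeps the core of compound 1 but differs on the sulfonamide nitrogen: 3-fluoro-4-methoxyphenyl in place of 3-amino-4-fluorophenyl on a sulfonamide nitrogen. For the measured compounds named here, with no measured step as a guide, a move toward stronger inhibition in this assay is expected, although a result with no change beyond the scatter remains possible. The expected size of the change is a 33-fold lower number from compound 1 to compound 4 (1.52 log units; beyond the scatter). For compound 4, the estimated value is 300 nM, with an expected range of 10 nM to 10000 nM.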

Compound 4, half-maximal inhibitory concentration: 200 nM
Compound 4: the middle estimate sits 1.5-fold (0.18 log units) above what was measured, and the stated range covers the measured number.
By their numbers in this assay, from the lowest: compound 4; then compounds 1, 2 and 3 (each within the scatter of the next).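

In this assay, 3-fluoro-4-methoxyphenyl in place of 3-amino-4-fluorophenyl on a sulfonamide nitrogen gives a 50-fold lower number from compound 1 to compound 4 (1.70 log units; beyond the scatter), a large step and the only one measured here. It shows that, with the core of compound 1 kept, the group on this nitrogen can move the number well beyond the scatter. Nothing at hand explains why the step is this large. The compounds shown leave open which part of the change carries the step, the loss of the amine or the gain of the methoxy group. On these data alone, whether an ethoxy group or a hydroxyl in place of that methoxy group would keep the lower number also stays open.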